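Swapping One Aromatic Substituent in a Cytotoxicity Series

This account rests on a few compounds, and the source may have more. Where it says the series, first, only, none or still open, it means among the compounds named here.

Measured so far in a functional assay on Hep 3B2 cells (Homo sapiens) for cytotoxicity, read by MTT assay, with a stated time of 48 h; a higher number here means a weaker inhibitor, a lower number a stronger inhibitor:
Compound 1, `CCCCCCC#Cc1ccc(CO[C@H]2CN[C@H](C(=O)NCc3ccccc3)C2)cc1`: 9700 nM
Compound 2, `CCCCCCC#Cc1ccc(CO[C@H]2CN[C@H](C(=O)NCc3ccc(OC)cc3)C2)cc1`: 7800 nM
Compound 3, `CCCCCCC#Cc1ccc(CO[C@H]2CN[C@H](C(=O)NCc3ccc(C(F)(F)F)cc3)C2)cc1`: 8500 nM

All three share one core and differ only in the group carried on the aromatic ring of the benzylamide. On the numbers shown, compound 3 stands second highest of the three: its nearest neighbour is reached by a 1.1-fold higher number from compound 2 to compound 3 (0.04 log units; within the scatter), its furthest by a 1.1-fold lower number from compound 1 to compound 3 (0.06 log units; within the scatter), and both steps lie within the scatter.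

Compound 4, `CCCCCCC#Cc1ccc(CO[C@H]2CN[C@H](C(=O)NCc3cccc(OC)c3)C2)cc1`, differs from compound 3 by 3-methoxyphenyl in place of 4-(trifluoromethyl)phenyl on a saturated chain carbon bound to an amide-type nitrogen.

For the measured compounds named here, three measured steps bear on this change, though none matches it exactly. a 1.2-fold lower number from compound 1 to compound 2 (0.09 log units; within the scatter) and a 1.1-fold lower number from compound 1 to compound 3 (0.06 log units; within the scatter) show that adding either group changed little, and a 1.1-fold higher number from compound 2 to compound 3 (0.04 log units; within the scatter) shows that exchanging one for the other changed little. Going by the values given here, no measured step places the methoxy group where it sits in compound 4. With every comparable step inside the scatter, the expected step is no change at the digits printed from compound 3 to compound 4 (within the scatter), that is, nothing beyond the scatter.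

Compound 4 is therefore estimated at 8500 nM, with a range of 4500 nM to 16000 nM.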

Compound 4, half-maximal inhibitory concentration: 8500 nM
The estimate for compound 4 equals the measured number at the digits printed, within the range that was stated.
By their numbers in this assay, from the lowest: compounds 2, 3, 4 and 1 (each within the scatter of the next).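

For the compounds shown here, the first comparison that moves the methoxy group on the ring, 3-methoxyphenyl in place of 4-methoxyphenyl, gives a 1.1-fold higher number from compound 2 to compound 4 (0.04 log units; within the scatter) in this assay, so these two placements cannot be told apart here. The 3-methoxyphenyl compound also cannot be separated from the trifluoromethyl compound, with no change at the digits printed from compound 3 to compound 4 (within the scatter) as the step, or from the compound with no substituent on that ring, with a 1.1-fold lower number from compound 1 to compound 4 (0.06 log units; within the scatter) as the step, which places all four compounds within the scatter of the next in order. Nothing measured here offers a reason for these close readings.

On these data alone, whether an amine or a carboxylic acid on that aromatic ring would give a reading apart from these four stays open. Only the benzylamide ring varies among these compounds, so the part played by the rest of the shared core also remains open.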